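Changing the Amide Aryl Group: Expected Cytotoxicity of Compound 3

The compounds below may be only part of what the source reports. "The series", "measured", "known", "first", "only" and "open" are said of these compounds alone.

Measured compounds:
Compound 1 `O=C(CSc1snnc1-c1ccc(Br)cc1Br)Nc1ccccc1F`: in an ADME assay on MT4 cells (Homo sapiens) for cytotoxicity, read by MTT assay, with a stated time of 5 days (on this read-out higher numbers stand for lower toxicity in this test and lower numbers for higher toxicity in this test), compound 1 gives >= 27800 nM, a limit of the assay.
Compound 2 `Cc1cccc(C)c1NC(=O)CSc1snnc1-c1ccc(Br)cc1Br`: in this assay compound 2 gives >= 198000 nM, also a limit of the assay.

Compound 2 stands at a limit of the assay, so its value in this assay is not a number. the limit of >= 198000 nM in this assay, at which 1 of the 2 values shown sits, marks where compound 2 sits, and the limit of >= 27800 nM in this assay, at which 1 of the 2 values shown sits, marks where compound 1 sits. The step that the two limits leave unreadable from compound 1 to compound 2 therefore cannot be read in size or direction. Compound 3 `O=C(CSc1snnc1-c1ccc(Br)cc1Br)Nc1cccnc1Cl` differs from compound 2 in one place: 2-chloropyridin-3-yl in place of 2,6-dimethylphenyl on an amide-type nitrogen. Among the compounds with values here, the only measured step, from compound 1 to compound 2, concerns the same position. Within the data shown here, both of its ends are limits, and it gives no readable size, so no measured step bears usefully on the change to compound 3. Both measured compounds reach only limits in this assay, and no step beyond the scatter can be expected from that alone. Compound 3 is expected to show 150000 nM in this assay, with a range from 30000 nM to 400000 nM, and the chance is high that the assay again reports only a limit. The step of an at least 1.3-fold lower number from compound 2 to compound 3 (0.12 log units; that floor lies within the scatter) is accordingly expected to stay within what the two limits allow.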

Compound 3, half-maximal cytotoxic concentration: > 240000 nM
Compound 3: only a limit was reported (the forecaster's own chance of this, stated with the estimate: 75%); middle value at least 1.6-fold (0.20 log units) from the limit.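

In this assay, within the data shown here, compound 3 gives > 240000 nM, again a limit of the assay and not a number, and no step among compound 1, compound 2 and compound 3 can be read in size or direction. The compounds shown leave open where the half-maximal cytotoxic concentrations of all three lie, and whether the group on the amide-type nitrogen changes them at all.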